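The source may hold more compounds than are shown below. What is called first, only, known or untested is meant among the compounds shown, and "the series" means these compounds.

In a physicochemical assay for lipophilicity, in phosphate buffer, measured as octanol-water partition, at pH 11.5 (a lower number here means a more polar compound, a higher number a more lipophilic compound), two compounds have been measured so far. Compound 1 `CCCCCCCCNC(=N)NC(=N)Nc1ccccc1` gives 4.43, and compound 2 `CCCCOC(=N)NC(=N)Nc1ccc(Cl)cc1` gives 3.32. Compound 2 is therefore the lower of the two, and the gap lies beyond the scatter. These two structures differ in more than one place, so the gap cannot be read as the result of any single change.

The next compound to be measured is compound 3 `CCCCCCCCOC(=N)NC(=N)Nc1ccc(Cl)cc1`. Relative to compound 2, the change is butyl in place of hydrogen on a saturated chain carbon, four bonds along the chain from an oxygen on an unsaturated carbon. The rest of the structure stays the same.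

Within the data shown here, no measured pair shows this change alone, so the data offer no direct precedent for its size. A clear rise in this assay is expected, well beyond the scatter. The estimated step of a number 1.88 log units higher from compound 2 to compound 3 (beyond the scatter) carries real uncertainty. In this assay, the estimated value for compound 3 is 5.2, with an expected range of 4.6 to 5.8.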

Compound 3, partition coefficient: 5.32
Beside the measured number, compound 3's estimate is 0.12 log units below it; the measured number falls inside the stated range.
By their numbers in this assay, from the lowest: compound 2; then compound 1; then compound 3.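

In this assay, the step of a number 2.00 log units higher from compound 2 to compound 3 (beyond the scatter) gives the series its first reading of a single change: butyl in place of hydrogen on a saturated chain carbon, four bonds along the chain from an oxygen on an unsaturated carbon. The earlier compounds shown here differed in more than one place, whereas this pair isolates one position and shows that the number there is sensitive to the change, with a large step. The entering butyl adds 4 carbon atoms, with no ring, no hydrogen-bond donors or acceptors and no net charge, and the rest of the structure stays the same. No measurement at hand bears on the reason for the size of this step.

A single pair gives two points on this chain and leaves open how the number moves in between, or whether a longer chain such as a decyl group would extend the rise. Also open, on these data alone, is how the same position responds to a polar end group on the chain, such as an amine or a carboxylic acid.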